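This account rests on a few compounds, and the source may have more. Where it says the series, first, only, none or still open, it means among the compounds named here.

Measured so far in a physicochemical assay, read by spectrophotometry, with a stated time of 30 min; on this read-out lower numbers stand for an effect already at smaller amounts and higher numbers for an effect only at larger amounts of compound (both values are limits):
- compound 1 `O=C1c2c(O)cc(O)cc2O[C@H](c2cccc(O)c2)[C@H]1O` gives > 100000 nM as a limit
- compound 2 `O=C1c2c(O)cc(O)cc2O[C@@H](c2ccccc2O)[C@@H]1O` gives > 100000 nM as a limit

Not yet measured: compound 3 `O=C1c2c(O)cc(O)cc2O[C@@H](c2cccc(O)c2)[C@@H]1O`

Compound 2 has no numerical value and stands only at a limit. Both measured compounds share the limit of > 100000 nM in this assay, at which 2 of the 2 values shown sit, and so cannot be ranked against each other. Compound 3 differs from compound 2 by 3-hydroxyphenyl in place of 2-hydroxyphenyl on a saturated ring carbon and carries 3-hydroxyphenyl in place of 2-hydroxyphenyl on a saturated ring carbon, next to the ring oxygen. Among the measured compounds shown here, no measured step in this assay gives a size for this change. Compound 1 also carries 3-hydroxyphenyl, and its reading of > 100000 nM is likewise a limit, so no gain is expected. The estimated a number no higher from compound 2 to compound 3 (the limit leaves the size open) is expected to stay within the usual scatter. Compound 3 is expected at 100000 nM, with an estimated range from 40000 nM to 200000 nM, and will probably be reported only as a limit.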

Compound 3, half-maximal effective concentration: > 100000 nM
Compound 3: no number, only a limit; the forecaster's own chance of this, stated with the estimate: 85%; the middle value lies on the limit itself.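

No step among compound 1, compound 2 and compound 3 can be read in this assay: the limit of > 100000 nM in this assay, at which 3 of the 3 values shown sit.

The compounds shown leave open whether 3-hydroxyphenyl in place of 2-hydroxyphenyl, or the mirror-image configuration separating compound 1 and compound 3, changes the read-out at all.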